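This account rests on a few compounds, and the source may have more. Where it says the series, first, only, none or still open, it means among the compounds named here.

Measured so far, in a functional assay on the whole organism (stomach) with Rattus norvegicus as the target; on this read-out lower numbers stand for an effect already at smaller amounts and higher numbers for an effect only at larger amounts of compound:
compound 1, `C/N=C(/NC#N)NCCCn1nc(-c2ccccc2)ccc1=O`, gives > 100 mg/kg, which is a limit of the assay and not a number.
compound 2, `CC/N=C(\S)NCCCCCn1nc(-c2ccccc2)ccc1=O`, gives 51.8 mg/kg.

Compound 2 thus holds the only number shown in this assay; the one further value is a limit, (the limit of > 100 mg/kg in this assay, at which 1 of the 2 values shown sits). For the measured compounds named here, the single measured step, an at least 1.9-fold lower number from compound 1 to compound 2 (0.28 log units; that floor lies within the scatter), exchanged the group on a saturated chain carbon three bonds along the chain from an aromatic nitrogen, and its floor lies within the scatter. Compound 3, `C/N=C(/NC#N)N(C)CCCCn1nc(-c2ccccc2)ccc1=O`, is not yet measured. Relative to compound 2 the change is a group of 8 heavy atoms (4 carbon, 4 nitrogen; no ring) in place of a group of 7 heavy atoms (4 carbon, 2 nitrogen, 1 sulfur; no ring), on a saturated chain carbon, four bonds along the chain from an aromatic nitrogen. The group that leaves resembles the one that entered in the measured step, and the group that enters resembles the one that left there, now carrying an added methyl and placed one carbon further along the chain. Going by the values given here, since the only precedent lowered the number by a floor within the scatter, the return is expected to raise it by a modest amount, with a real chance of a limit again. Compound 3 is therefore expected at 85 mg/kg, range 35 mg/kg to 200 mg/kg, the expected step being a 1.6-fold higher number from compound 2 to compound 3 (0.22 log units; within the scatter).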

Compound 3, dose for half-maximal effect: > 100 mg/kg
Compound 3 ended at the assay's limit; the forecaster's own chance of this, stated with the estimate: 40%; middle value at least 1.1-fold (0.07 log units) away from the limit.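

In this assay compound 3 gives > 100 mg/kg, which is a limit of the assay and not a number. The exchange on a saturated chain carbon, four bonds along the chain from an aromatic nitrogen, is an at least 1.9-fold higher number from compound 2 to compound 3 (0.28 log units; that floor lies within the scatter), so this floor alone does not separate the group of 8 heavy atoms from the sulfur-bearing group of 7 heavy atoms. The new point is that a second nitrile-bearing compound joins compound 1 without a number, leaving compound 2 the only compound with one in this assay, and the limit now holds most of the series: the limit of > 100 mg/kg in this assay, at which 2 of the 3 values shown sit.

The compounds shown leave open how far compound 1 and compound 3 lie beyond the limit, and whether the sulfur atom, the nitrile, the added methyl or the chain accounts for the number of compound 2. Also open, going by these compounds, is whether a longer chain, or an amine or a carboxylic acid in place of these groups at the same chain carbon, would give a measured number in this assay.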